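The source may report more compounds than this note shows. Statements on the series, on what has been measured and on what is new or still open speak of the compounds shown alone.

Compounds measured so far:
- compound 1, `CC[C@]1(c2ccsc2)OC[C@H]([C@@H]2CCCCN2)O1`: 124 nM
- compound 2, `CCCN1CCCC[C@H]1[C@H]1COC(c2ccccc2)(c2ccccc2)O1`: 6800 nM
- compound 3, `C[C@H](N)[C@H]1COC(c2ccccc2)(c2ccccc2)O1`: 607 nM

All three were tested in a functional assay (brain) for displacement of a labelled ligand, with Rattus norvegicus as the target; a lower number here means a stronger inhibitor, a higher number a weaker inhibitor. Compound 3 sits second highest of the three numbers: compound 1 gives 124 nM, a markedly lower number, and compound 2 gives 6800 nM, a markedly higher one, so compound 3 lies between them with clear gaps to each side. Compound 1 and compound 2 differ from compound 3 in more than one place, so neither offers a clean single change to read from.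

Compound 4, `CCN[C@@H](C)[C@H]1COC(c2ccccc2)(c2ccccc2)O1`, has not yet been measured. It differs from compound 3 in one place only:

ethyl in place of hydrogen on an amine nitrogen

Among the measured compounds shown here, no measured pair here isolates this kind of change, so there is no direct step to lean on. Compound 2, which carries a larger alkyl group on its ring nitrogen, gives the highest number of the set, which hints that adding carbon on the amine may weaken binding, but that is a loose hint only. The step from compound 3 to compound 4 is expected to be small, somewhat toward a higher number, and possibly within the scatter, as a 1.5-fold higher number from compound 3 to compound 4 (0.17 log units; within the scatter).

For compound 4 the expected value in this assay is 900 nM, with a range from 300 nM to 3000 nM.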

Compound 4, inhibition constant: 9000 nM
The estimate for compound 4 lay 10-fold (1.00 log units) below the measured number, outside the stated range (above it).
By their numbers in this assay, from the lowest: compound 1; then compound 3; then compounds 2 and 4 (each within the scatter of the next).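

Ethyl in place of hydrogen on the amine nitrogen gives a 15-fold higher number from compound 3 to compound 4 (1.17 log units; beyond the scatter) in this assay for this pair, the first step in the set that changes only one place. It shows directly that, with the shared core held constant, turning the 1-aminoethyl group into 1-(ethylamino)ethyl weakens the compound sharply, so this nitrogen is a sensitive position rather than one where added carbon makes little difference. No measurement shown explains why the step is so large.

The compounds shown leave open whether a smaller methyl group or a longer chain such as butyl on this nitrogen would give a step of similar size. They also leave open whether ethyl on the ring nitrogen of compound 1 would raise the number as strongly.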